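Halogen swap on the benzyl group: the bromo analogue

The source may hold more compounds than are shown below. What is called first, only, known or untested is meant among the compounds shown, and "the series" means these compounds.

The series shares one core; compound 1 `Fc1ccc(CSc2nnc(-c3ccc4c(c3)OCCO4)o2)cc1` and compound 2 `Clc1ccc(CSc2nnc(-c3ccc4c(c3)OCCO4)o2)cc1` differ only in the halogen on the benzyl ring. In a functional assay on BGC-823 cells (Homo sapiens) for antiproliferative activity, read by MTT assay, with a stated time of 48 h (on this read-out lower numbers stand for stronger inhibition and higher numbers for weaker inhibition), compound 1 gives 28700 nM, the higher of the two numbers shown, though the gap to compound 2, which gives 22600 nM, stays within the scatter. For the measured compounds named here, the single measured step, a 1.3-fold lower number from compound 1 to compound 2 (0.10 log units; within the scatter), is chloro in place of fluoro on an aromatic carbon.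

Compound 3 `Brc1ccc(CSc2nnc(-c3ccc4c(c3)OCCO4)o2)cc1` carries the next halogen: bromo in place of fluoro on an aromatic carbon, placed on an aromatic carbon of a six-membered aromatic ring of carbon only, para to a large group. Going by the values given here, the only step that bears on it is a 1.3-fold lower number from compound 1 to compound 2 (0.10 log units; within the scatter), and a second halogen swap at the same place is expected to behave alike, so no step beyond the scatter is expected in this assay. For compound 3 the expected step is a 1.4-fold lower number from compound 1 to compound 3 (0.16 log units; within the scatter). Compound 3 is therefore estimated at 20000 nM, with a range from 8000 nM to 50000 nM.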

Compound 3, half-maximal inhibitory concentration: 22300 nM
For compound 3 the middle estimate is 1.1-fold (0.05 log units) below the measured one; the measured number falls inside the stated range.
By their numbers in this assay, from the lowest: compounds 3, 2 and 1 (each within the scatter of the next).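

With bromo now read at this place, on an aromatic carbon of a six-membered aromatic ring of carbon only, para to a large group, this assay shows bromo in place of fluoro as a 1.3-fold lower number from compound 1 to compound 3 (0.11 log units; within the scatter), and bromo in place of chloro as a 1.0-fold lower number from compound 2 to compound 3 (0.01 log units; within the scatter). Compound 1, compound 2 and compound 3 therefore stand within the scatter of one another, so this halogen change does not separate these three compounds in this read-out. No evidence is at hand that bears on this result.

Open, going by these compounds, is whether a group other than a halogen at this place, such as a methoxy group, a nitrile, an amine or a carboxylic acid, would give a step beyond the scatter. Also open, on these data alone, is how a longer chain would read in place of the 4-bromobenzyl group on the shared core.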